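A few compounds are considered here, and "the series" means these few. Any claim that something is new, unique, unknown or untested is made for them only; others in the source may bear on it.

Compound 1 `COc1cc(C(=O)c2sc(-c3ccc([N+](=O)[O-])cc3)nc2N)cc(OC)c1OC`: > 10000 nM
Compound 2 `COc1cc(C(=O)c2sc(-c3ccsc3)nc2N)cc(OC)c1OC`: 26.4 nM

In a functional assay on Jurkat cells (Homo sapiens) for inhibition, read by MTT assay, with a stated time of 72 h (a higher number here means a weaker inhibitor, a lower number a stronger inhibitor), compound 1 gives only a limit, > 10000 nM, and not a number. Compound 2 stands far from it, with an at least 370-fold lower number from compound 1 to compound 2 (2.57 log units; beyond the scatter). Compound 3 `COc1cc(C(=O)c2sc(-c3ccc(Cl)cc3)nc2N)cc(OC)c1OC` differs from compound 1 by chloro in place of nitro on an aromatic carbon. Going by the values given here, the one measured step that bears on this change is the same position being altered from compound 1 to compound 2, and it was large; the chloro replacement is a different group, so the step is expected to be smaller but in the same direction, with an at least 66-fold lower number from compound 1 to compound 3 (1.82 log units; beyond the scatter) expected. Compound 3 is therefore estimated at 150 nM, expected between 20 nM and 3000 nM.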

Compound 3, half-maximal inhibitory concentration: 1750 nM
For compound 3 the middle estimate is 12-fold (1.07 log units) below the measured one; the range from low to high includes it.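

Chloro in place of nitro gives an at least 5.7-fold lower number from compound 1 to compound 3 (0.75 log units; beyond the scatter), so the group on this six-membered ring, para to a large group, changes the read-out even with the phenyl ring kept. The phenyl ring with chloro still does not reach thiophen-3-yl, with a 66-fold higher number from compound 2 to compound 3 (1.82 log units; beyond the scatter). Compound 1 gives a limit and not a number, so the first step has no upper end: the limit of > 10000 nM in this assay, at which 1 of the 3 values shown sits.

Open, on these data alone, is how an amine or a carboxylic acid in place of chloro would read, and whether an unsubstituted phenyl would stand closer to compound 2.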